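Series notes: methoxy to chloro on the pendant aryl

A few compounds are considered here, and "the series" means these few. Any claim that something is new, unique, unknown or untested is made for them only; others in the source may bear on it.

Compound 3 `COc1ccc(C2=NN(C3=NC(=O)/C(=C4\C(=O)Nc5ccc(Cl)cc54)S3)C(c3ccc(OC)cc3)C2)cc1` stands lowest of the three numbers measured in a functional assay on cells (Cancer cell lines, Homo sapiens) for cytotoxicity, read by sulforhodamine B assay, with a stated time of 48 h (a lower number here means a stronger inhibitor of growth, a higher number a weaker inhibitor of growth), where compound 3 gives 190 nM. Compound 2 `COc1ccc(C2=NN(C3=NC(=O)/C(=C4\C(=O)Nc5ccc(Br)cc54)S3)C(c3ccc(OC)cc3)C2)cc1` lies closest, with compound 2 giving 200 nM; the step of a 1.1-fold lower number from compound 2 to compound 3 (0.02 log units; within the scatter) is within the scatter, so the two cannot be ordered. For the measured compounds named here, compound 1 `O=C1N=C(N2N=C(c3ccccc3)CC2c2ccccc2O)S/C1=C1/C(=O)Nc2ccccc21` is furthest away, and compound 1 gives 2070 nM, which differs from compound 3 in several places at once, so no single step can be drawn from it.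

Compound 4 `COc1ccc(C2=NN(C3=NC(=O)/C(=C4\C(=O)Nc5ccc(Cl)cc54)S3)C(c3ccc(Cl)cc3)C2)cc1` is not yet measured. It differs from compound 3 by chloro in place of methoxy on an aromatic carbon. Going by the values given here, no measured step touches this position or this exchange; the only one-place step available, from compound 2 to compound 3, swaps one halogen for another elsewhere on the core and stays within the scatter. There is therefore no basis for expecting a directional change, and the expected step of a 1.3-fold higher number from compound 3 to compound 4 (0.12 log units; within the scatter) is estimated to fall within the scatter. Compound 4 is expected to give 250 nM in this assay, with a range from 100 nM to 650 nM.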

Compound 4, concentration for 50% growth inhibition: 200 nM
The estimate for compound 4 lay 1.3-fold (0.10 log units) above the measured number; the range from low to high includes it.
By their numbers in this assay, from the lowest: compounds 3, 2 and 4 (each within the scatter of the next); then compound 1.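

In this assay, for the compounds shown here, the first reading at this position is a 1.1-fold higher number from compound 3 to compound 4 (0.02 log units; within the scatter), so 4-methoxyphenyl and 4-chlorophenyl cannot be told apart here. The group that leaves carries a hydrogen-bond acceptor and the group that enters carries none, so at this position, para to a large group, this assay does not require that acceptor, at least with the second 4-methoxyphenyl group in place. Nothing available explains why compound 3 and compound 4 read alike.

On these data alone, one exchange at one position cannot show how much this position tolerates, and it remains open whether an amine, a carboxylic acid or a longer alkoxy chain would read the same. Also open, as far as these compounds go, is whether chloro at this position would read the same with bromo in place of the chloro on the shared core.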